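The source may hold more compounds than are shown below. What is called first, only, known or untested is meant among the compounds shown, and "the series" means these compounds.

Measured compounds:
compound 1, `CC[C@H](C)C(=O)O[C@H]1C[C@H](O)C=C2C=C[C@H](C)[C@H](CCC(O)C[C@H](O)CC(=O)O)[C@]21C`: in an assay on microsomes from liver for inhibition of 3-hydroxy-3-methylglutaryl-coenzyme A reductase (Rattus norvegicus) (on this read-out higher numbers stand for weaker inhibition and lower numbers for stronger inhibition), compound 1 gives 5 nM
compound 2, `O=C(O)C[C@H](O)C[C@H](O)CCn1c(C(F)(F)F)nc(-c2ccc(F)cc2)c1-c1ccc(F)cc1`: in this assay compound 2 gives 38 nM
compound 3, `COc1ccc(-c2nc(C(F)(F)F)n(CC[C@@H](O)C[C@@H](O)CC(=O)O)c2-c2ccc(F)cc2)cc1`: in this assay compound 3 gives 68 nM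

Compound 3 stands at the highest of the three numbers. Its nearest neighbour is compound 2, and the step of a 1.8-fold higher number from compound 2 to compound 3 (0.25 log units; within the scatter) lies within the scatter. Compound 1 sits clearly lower, a gap beyond the scatter.

Compound 4, `Cc1cc(-c2nc(C(F)(F)F)n(CC[C@@H](O)C[C@@H](O)CC(=O)O)c2-c2ccc(F)cc2)cc(C)c1F`, differs from compound 3 in one place: 4-fluoro-3,5-dimethylphenyl in place of 4-methoxyphenyl on an aromatic carbon. Going by the values given here, the one measured step that touches this position is the one from compound 2 to compound 3, an exchange of one group for another on the same aromatic carbon, and that step stayed within the scatter. On this basis no step beyond the scatter is expected in this assay for the move from compound 3 to compound 4; the expected step is a 1.5-fold lower number from compound 3 to compound 4 (0.18 log units; within the scatter). Compound 4 is therefore estimated at 45 nM, with a range from 15 nM to 150 nM.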

Compound 4, half-maximal inhibitory concentration: 32 nM
Beside the measured number, compound 4's estimate is 1.4-fold (0.15 log units) above it; low and high end bracket the measured number.
By their numbers in this assay, from the lowest: compound 1; then compounds 4, 2 and 3 (each within the scatter of the next, the first and the last beyond it).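

In this assay, going by these compounds alone, the step of a 2.1-fold lower number from compound 3 to compound 4 (0.33 log units; beyond the scatter) is the first at this aromatic carbon to pass beyond the scatter, although only modestly, so the choice of aryl group here can shift the number measurably. Set against the 4-fluorophenyl group, however, the 4-fluoro-3,5-dimethylphenyl group gives a 1.2-fold lower number from compound 2 to compound 4 (0.07 log units; within the scatter), which stays within the scatter, so the compounds shown do not separate these two groups, and the methyl pair brings no measurable change on the fluorinated ring. Nothing on hand explains either step. Going by these compounds, it remains open what a 3,5-dimethylphenyl group without the fluorine would give at this carbon, which would separate the methyl pair from the fluoro group. On these data alone, it also remains open whether a 4-aminophenyl group or a 4-carboxyphenyl group would be accommodated there.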